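Swapping the Sulfonamide Heteroaryl in a Cytotoxicity Series

The compounds below may be only part of what the source reports. "The series", "measured", "known", "first", "only" and "open" are said of these compounds alone.

Compound 1 `C=C1CC[C@@H]2[C@](C)(COC(C)=O)[C@H](OC(C)=O)CC[C@@]2(C)[C@H]1CC(Nc1ccc(S(=O)(=O)Nc2ccc(Cl)nn2)cc1)C1=CCOC1=O` carries a 6-chloropyridazin-3-yl group on the sulfonamide nitrogen. In a functional assay on HCT-15 cells (Homo sapiens) for inhibition, read by sulforhodamine B assay, with a stated time of 48 h (a higher number here means that more compound is tolerated, a lower number that less compound is tolerated), compound 1 gives 5510 nM, the lowest of the two numbers recorded so far. Compound 2 `C=C1CC[C@@H]2[C@](C)(COC(C)=O)[C@H](OC(C)=O)CC[C@@]2(C)[C@H]1CC(Nc1ccc(S(=O)(=O)Nc2ncccn2)cc1)C1=CCOC1=O` gives 9150 nM in this assay, and the step of a 1.7-fold higher number from compound 1 to compound 2 (0.22 log units; within the scatter) amounts to nothing beyond the scatter. Compound 3 `C=C1CC[C@@H]2[C@](C)(COC(C)=O)[C@H](OC(C)=O)CC[C@@]2(C)[C@H]1CC(Nc1ccc(S(=O)(=O)Nc2nccs2)cc1)C1=CCOC1=O` has not yet been measured; its difference from compound 1 is 1,3-thiazol-2-yl in place of 6-chloropyridazin-3-yl on a sulfonamide nitrogen. For the measured compounds named here, the only measured step that bears on this change is the one from compound 1 to compound 2, which likewise replaces the same group on the sulfonamide nitrogen with another heteroaryl and stays within the scatter. The analyst therefore expects for compound 3 a step of a 1.3-fold higher number from compound 1 to compound 3 (0.10 log units; within the scatter), no larger than the scatter. Her estimate for compound 3 in this assay is 7000 nM, with a range from 3000 nM to 16000 nM.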

Compound 3, concentration lethal to 50% of the cells: 9840 nM
Compound 3: middle estimate off by 1.4-fold (0.15 log units), on the low side; measured number inside the range.
By their numbers in this assay, from the lowest: compounds 1, 2 and 3 (each within the scatter of the next).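

Placing a five-membered aromatic ring on the sulfonamide nitrogen gives, in this assay, a 1.8-fold higher number from compound 1 to compound 3 (0.25 log units; within the scatter), while 1,3-thiazol-2-yl in place of pyrimidin-2-yl gives a 1.1-fold higher number from compound 2 to compound 3 (0.03 log units; within the scatter). The three heteroaryl groups at this place therefore cannot be told apart in this read-out, and neither the change in ring size nor the loss of the chlorine of 6-chloropyridazin-3-yl takes the number beyond the scatter. Nothing measured here offers an explanation for this result.

As far as these compounds go, all three compounds keep a heteroaryl ring at this place, so it remains open whether a phenyl ring, a methyl group or a longer alkyl chain on the sulfonamide nitrogen would give a step beyond the scatter. From the compounds shown here alone, it also remains open whether the result would hold if hydroxyl groups replaced the acetate esters of the shared core.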